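Phenoxy in place of the amide on the anilide ring

The source may hold more compounds than are shown below. What is called first, only, known or untested is meant among the compounds shown, and "the series" means these compounds.

Compound 1 `O/N=C(/Nc1ccccc1)c1ccc2occc2c1` gives 19000 nM in an assay on tissue (HeLa cells) for inhibition of Indoleamine 2,3-dioxygenase 1 (Homo sapiens), read by spectrophotometry; a lower number here means a stronger inhibitor, a higher number a weaker inhibitor.
Compound 2 `O/N=C(/Nc1cccc(C(F)(F)F)c1)c1ccc2occc2c1` gives 1900 nM in this assay.
Compound 3 `CC1CCN(C(=O)c2cccc(N/C(=N/O)c3ccc4occc4c3)c2)CC1` gives in this assay only a limit of the assay, > 30000 nM.

Compound 3 therefore stands at the weak end of the three: no number is known for it, only the limit at which one of the three values sits (the limit of > 30000 nM in this assay, at which 1 of the 3 values shown sits). The two steps that lead to it are an at least 1.5-fold higher number from compound 1 to compound 3 (0.19 log units; that floor lies within the scatter) and an at least 15-fold higher number from compound 2 to compound 3 (1.19 log units; beyond the scatter), so the carbonyl-linked ring at that place is associated with the weakest result shown, whether the starting point is the unsubstituted compound 1 or compound 2.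

Compound 4 `O/N=C(/Nc1cccc(Oc2ccccc2)c1)c1ccc2occc2c1` is the next compound and differs from compound 3 in one place: phenoxy in place of (4-methylpiperidin-1-yl)carbonyl on an aromatic carbon. Both steps onto compound 3 bear directly on this change, since it removes the very group that carried compound 3 to the limit. The step of a 10-fold lower number from compound 1 to compound 2 (1.00 log units; beyond the scatter) further shows that a small substituent at this position in place of hydrogen can lower the number considerably.

On that basis compound 4 is expected to give a lower number than compound 3, by an estimated at least 7.5-fold lower number from compound 3 to compound 4 (0.87 log units; beyond the scatter). Compound 4 is estimated at 4000 nM, within a range of 900 nM to 18000 nM.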

Compound 4, half-maximal inhibitory concentration: > 30000 nM
Compound 4 gave a limit, no number (the forecaster's own chance of this, stated with the estimate: 10%); at least 7.5-fold (0.87 log units) between middle value and limit.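

Compound 4 also stops at a limit of the assay in this assay, so a second ring-bearing group at this place, this time with an aromatic ring of carbon only and no carbonyl, fails to keep the gain seen with trifluoromethyl in compound 2: an at least 15-fold higher number from compound 2 to compound 4 (1.19 log units; beyond the scatter). Against the unsubstituted compound, the reading is weaker: an at least 1.5-fold higher number from compound 1 to compound 4 (0.19 log units; that floor lies within the scatter), so phenoxy cannot be ranked against hydrogen, and the step between compound 3 and compound 4 cannot be read, as both are limits. Among these compounds, substitution at this place therefore no longer goes with a lower number in general, with compound 2 the only one of the three substituted compounds to show it, and the weak end is now shared: the limit of > 30000 nM in this assay, at which 2 of the 4 values shown sit.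

Going by these compounds, how far compound 3 and compound 4 lie past that limit stays open, and so does whether the two groups differ at all. Also open, on these data alone, is whether methoxy, an amine or a carboxylic acid at this place would stay close to compound 2 or fall to the same limit.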